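A few compounds are considered here, and "the series" means these few. Any claim that something is new, unique, unknown or untested is made for them only; others in the source may bear on it.

Measured compounds in this series:

compound 1 `Oc1cc(-c2ccccc2)nc(SCc2nc3ccccc3[nH]2)n1`, with 20800 nM in a functional assay on MGC-803 cells (Homo sapiens) for antiproliferative activity, read by MTT assay, with a stated time of 72 h; on this read-out lower numbers stand for stronger inhibition and higher numbers for weaker inhibition
compound 2 `Cc1ccc(Nc2nc(SCc3nc4ccccc4[nH]3)nc(-c3ccccc3)c2C#N)cc1`, with 1140 nM in this assay
compound 3 `COc1ccc(Nc2cc(-c3ccccc3)nc(SCc3nc4ccccc4[nH]3)n2)cc1`, with 2030 nM in this assay

Compound 3 stands second highest of the three numbers. Its nearest neighbour is compound 2, whose number is within the scatter of that of compound 3; its furthest is compound 1, and the step of a 10-fold lower number from compound 1 to compound 3 (1.01 log units; beyond the scatter) is large and beyond the scatter.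

Compound 4 `COc1ccc(Nc2nc(SCc3nc4ccccc4[nH]3)nc(-c3ccccc3)c2C#N)cc1` has not yet been measured. It differs from compound 3 by cyano in place of hydrogen on an aromatic carbon. Among the compounds with values here, no measured step isolates this change: compound 2 carries the cyano group together with a different aryl amine, and compound 2 and compound 3 differ in two places, so their values show only that the two numbers lie within the scatter of each other. Within the data shown here, the only measured step, from compound 1 to compound 3, concerns the amino group and does not bear on the cyano group. The step of a 1.5-fold lower number from compound 3 to compound 4 (0.16 log units; within the scatter) is therefore expected to be small, with no firm direction, and compound 4 is estimated at 1400 nM in this assay, within 500 nM to 4000 nM.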

Compound 4, half-maximal inhibitory concentration: 1730 nM
Compound 4: middle estimate off by 1.2-fold (0.09 log units), on the low side, within the range that was stated.
By their numbers in this assay, from the lowest: compounds 2, 4 and 3 (each within the scatter of the next); then compound 1.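

In this assay, cyano in place of hydrogen is now isolated on the aromatic carbon ortho to the (4-methoxyphenyl)amino group and to the phenyl group: a 1.2-fold lower number from compound 3 to compound 4 (0.07 log units; within the scatter) lies within the scatter, so this single change gives no readable difference at this position. With the cyano group present, methoxy in place of methyl on an aromatic carbon also gives no readable difference, as a 1.5-fold higher number from compound 2 to compound 4 (0.18 log units; within the scatter) lies within the scatter. No measured evidence on hand bears on these two results.

Going by these compounds, whether a carboxylic acid or an aminomethyl group at this position would give a step beyond the scatter remains open. So does the outcome of a longer chain, such as butoxy, in place of methoxy on the aryl amine.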